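This account rests on a few compounds, and the source may have more. Where it says the series, first, only, none or still open, it means among the compounds named here.

Compound 1 `COc1ccc(S(=O)(=O)N2CC(C(=O)NC3CCN(C)CC3)c3ccccc32)c2ccccc12` gives 25.1 nM in a functional assay on CHO cells for antagonist activity at 5-hydroxytryptamine receptor 6 (Homo sapiens), read by FLIPR; on this read-out lower numbers stand for stronger inhibition and higher numbers for weaker inhibition; compound 2 `CCN(CC)CCNC(=O)C1CN(S(=O)(=O)c2ccc(OC)c3ccccc23)c2ccccc21` gives 20 nM in this assay.

Compound 1 stands highest of the two numbers, with compound 2 nearest to it: a 1.3-fold lower number from compound 1 to compound 2 (0.10 log units; within the scatter). Compound 3 `COc1ccc(S(=O)(=O)N2CC(C(=O)NCCCn3ccnc3)c3ccccc32)c2ccccc12` differs from compound 1 by 3-(1H-imidazol-1-yl)propyl in place of 1-methylpiperidin-4-yl on an amide-type nitrogen. Within the data shown here, only the step from compound 1 to compound 2 bears on this exchange at the amide-type nitrogen, and that step stayed within the scatter, so no change beyond the scatter is expected in this assay in either direction. Compound 3 is therefore estimated at 25 nM, within 8 nM to 80 nM, an expected step of a 1.0-fold lower number from compound 1 to compound 3 (0.00 log units; within the scatter).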

Compound 3, inhibition constant: 79.4 nM
The estimate for compound 3 lay 3.2-fold (0.50 log units) below the measured number; low and high end bracket the measured number.
By their numbers in this assay, from the lowest: compounds 2 and 1 (each within the scatter of the next); then compound 3.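

In this assay the amide-type nitrogen turns out to be a place where the substituent can matter: 3-(1H-imidazol-1-yl)propyl in place of 1-methylpiperidin-4-yl gives a 3.2-fold higher number from compound 1 to compound 3 (0.50 log units; beyond the scatter) and the matching exchange against the diethylamino chain gives a 4.0-fold higher number from compound 2 to compound 3 (0.60 log units; beyond the scatter) as the second modest step. Both steps go towards weaker inhibition and lie beyond the scatter, unlike the earlier exchange at this nitrogen. Nothing measured here accounts for this loss.

The compounds shown leave open whether the step follows the imidazole ring or the chain carrying it. A propyl chain ending in dimethylamino, or a longer chain ending in the same imidazole, would separate the two.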